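A few compounds are considered here, and "the series" means these few. Any claim that something is new, unique, unknown or untested is made for them only; others in the source may bear on it.

Compounds measured so far:
compound 1 `CNc1nc(Nc2cnn(CCCCCCC(=O)NO)c2)ncc1Cl` — 590 nM
compound 2 `O=C(CCCCCCn1cc(Nc2ncc(Cl)c(Nc3ccc(F)cc3)n2)cn1)NO` — 500 nM
compound 3 `O=C(CCCCCCn1cc(Nc2ncc(Cl)c(Nc3cccc(Cl)c3)n2)cn1)NO` — 380 nM

In a functional assay on K562 cells (Homo sapiens) for antiproliferative activity, read by MTT assay, with a stated time of 48 h (on this read-out lower numbers stand for stronger inhibition and higher numbers for weaker inhibition), compound 3 has the lowest number of the three, but its steps to the other two, a 1.3-fold lower number from compound 2 to compound 3 (0.12 log units; within the scatter) and a 1.6-fold lower number from compound 1 to compound 3 (0.19 log units; within the scatter), both lie within the scatter, so the three compounds cannot be ordered on these numbers. Compound 4 `O=C(CCCCCCn1cc(Nc2ncc(Cl)c(Nc3ccc(Cl)cc3)n2)cn1)NO` is the next member: 4-chlorophenyl in place of 3-chlorophenyl on a nitrogen on an aromatic ring. The earlier steps shown here on this nitrogen, a 1.2-fold lower number from compound 1 to compound 2 (0.07 log units; within the scatter), a 1.6-fold lower number from compound 1 to compound 3 (0.19 log units; within the scatter) and a 1.3-fold lower number from compound 2 to compound 3 (0.12 log units; within the scatter), show that replacing methyl by either aryl group, or swapping one aryl group for another, left this assay essentially unchanged. Among the measured compounds shown here, no step has yet moved beyond the scatter, and nothing in the data separates a 4-chlorophenyl from a 3-chlorophenyl. The expectation for compound 4 is therefore a number close to that of compound 3, with the step of a 1.1-fold higher number from compound 3 to compound 4 (0.04 log units; within the scatter) expected to fall within the scatter. Compound 4 is estimated at 420 nM, in the range 200 nM to 900 nM.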

Compound 4, half-maximal inhibitory concentration: 320 nM
Estimate against measurement, compound 4: 1.3-fold (0.12 log units) above; measured number inside the range.
By their numbers in this assay, from the lowest: compounds 4, 3, 2 and 1 (each within the scatter of the next).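

In this assay, 4-chlorophenyl in place of 3-chlorophenyl on this nitrogen gives a 1.2-fold lower number from compound 3 to compound 4 (0.07 log units; within the scatter), so these numbers do not distinguish the two chlorine placements on the aryl ring. Chloro in place of fluoro on an aromatic carbon gives a 1.6-fold lower number from compound 2 to compound 4 (0.19 log units; within the scatter), and 4-chlorophenyl in place of methyl gives a 1.8-fold lower number from compound 1 to compound 4 (0.27 log units; within the scatter), the largest step in the series so far, though the aryl groups and methyl still cannot be told apart. Nothing available bears on why these groups sit so close in this assay.

Going by these compounds, whether a carboxylic acid, a morpholine or a cyclopropyl on this nitrogen would take a step beyond the scatter stays open. On these data alone, the heptanoyl hydroxamic acid chain is common to all four compounds, and what a shorter or longer chain would do is equally open.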